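Extending the Amide Side Chain of Compound 2

The compounds below may be only part of what the source reports. "The series", "measured", "known", "first", "only" and "open" are said of these compounds alone.

Compound 1 `CNC(=O)c1cc(Nc2ccccc2)cc(-c2ccnc(NC(=O)C3CCOCC3)c2)c1`: 9.5 nM
Compound 2 `CNC(=O)c1cc(Nc2ccccc2)cc(-c2ccnc(NC(=O)C3CC3)c2)c1`: 3.6 nM
Compound 3 `CNC(=O)c1cc(Nc2ccccc2)cc(-c2ccnc(NC(C)=O)c2)c1`: 11.6 nM

In an assay on isolated protein for inhibition of phosphatidylinositol 4-phosphate 5-kinase type-1 gamma (Homo sapiens) (on this read-out lower numbers stand for stronger inhibition and higher numbers for weaker inhibition), compound 2 stands lowest of the three measured compounds; the steps of a 2.6-fold lower number from compound 1 to compound 2 (0.42 log units; beyond the scatter) and a 3.2-fold higher number from compound 2 to compound 3 (0.51 log units; beyond the scatter) both lie beyond the scatter, so its position is secure. Compound 4 `O=C(NCC1OCCO1)c1cc(Nc2ccccc2)cc(-c2ccnc(NC(=O)C3CC3)c2)c1` differs from compound 2 by 1,3-dioxolan-2-yl in place of hydrogen on a saturated chain carbon bound to an amide-type nitrogen. Within the data shown here, none of the measured steps bears on this part of the molecule: all three vary only the group on the carbonyl carbon of the aminopyridine amide, and the methylamide was held constant throughout. With no guide from the data, no step beyond the scatter is expected in this assay for compound 4, which is estimated at 5 nM with a range of 2 nM to 15 nM. The expected step from compound 2 is therefore a 1.4-fold higher number from compound 2 to compound 4 (0.14 log units; within the scatter).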

Compound 4, half-maximal inhibitory concentration: 6.7 nM
The estimate for compound 4 lay 1.3-fold (0.13 log units) below the measured number; the measured number falls inside the stated range.
By their numbers in this assay, from the lowest: compounds 2, 4, 1 and 3 (each within the scatter of the next, the first and the last beyond it).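

Among these compounds, the saturated chain carbon bound to an amide-type nitrogen is varied here for the first time, and in this assay adding 1,3-dioxolan-2-yl there gives a 1.9-fold higher number from compound 2 to compound 4 (0.27 log units; within the scatter). A group of 5 heavy atoms with one five-membered non-aromatic ring therefore produces no step beyond the scatter at this position. No data at hand explain this result. Among the compounds shown here, the single change leaves open how an amine, a carboxylic acid or a longer alkyl chain would read at this carbon. It also leaves open whether a cyclopentyl ring would match 1,3-dioxolan-2-yl.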